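A few compounds are considered here, and "the series" means these few. Any claim that something is new, unique, unknown or untested is made for them only; others in the source may bear on it.

In a functional assay on K562 cells (Homo sapiens) for cytotoxicity, read by trypan blue exclusion, with a stated time of 96 h (on this read-out lower numbers stand for stronger inhibition and higher numbers for weaker inhibition), three compounds built on one shared core have been measured. Compound 1 (`COC(=O)C(Nc1cc(CS(=O)(=O)/C=C/c2c(OC)cc(OC)cc2OC)ccc1OC)c1ccc(F)cc1`) gives 800 nM and compound 2 (`COc1cc(OC)c(/C=C/S(=O)(=O)Cc2ccc(OC)c(NC(C)(C)C(=O)O)c2)c(OC)c1`) gives 7.5 nM while compound 3 (`COc1cc(OC)c(/C=C/S(=O)(=O)Cc2ccc(OC)c(NC(C(=O)O)c3ccc(Br)cc3)c2)c(OC)c1`) gives 200 nM as the second highest of the three numbers. Compound 3 therefore stands nearer to compound 1 than to compound 2. Compound 4 (`COc1ccc(C(Nc2cc(CS(=O)(=O)/C=C/c3c(OC)cc(OC)cc3OC)ccc2OC)C(=O)O)cc1`) has not yet been measured and carries methoxy in place of bromo on an aromatic carbon para to a large group.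

Among the compounds with values here, no measured step isolates this change. The closest evidence is a 4.0-fold lower number from compound 1 to compound 3 (0.60 log units; beyond the scatter) which is modest, but there 4-fluorophenyl becomes 4-bromophenyl while methoxycarbonyl becomes carboxy, so the two changes cannot be separated. The large steps, a 110-fold lower number from compound 1 to compound 2 (2.03 log units; beyond the scatter) and a 27-fold higher number from compound 2 to compound 3 (1.43 log units; beyond the scatter) as well, exchange the whole group on the nitrogen, and the aromatic ring is lost or gained with it. They say little about a swap that leaves this ring in place. Only a small shift is therefore expected in this assay and its direction is uncertain. The expected change is a 1.2-fold lower number from compound 3 to compound 4 (0.07 log units; within the scatter) and is not expected to go beyond the scatter. For compound 4 the estimate is 170 nM with an expected range from 55 nM to 550 nM in this assay.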

Compound 4, half-maximal inhibitory concentration: 15 nM
Beside the measured number, compound 4's estimate is 11-fold (1.05 log units) above it; measured number below the stated range.
By their numbers in this assay, from the lowest: compounds 2 and 4 (each within the scatter of the next); then compound 3; then compound 1.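

With the aromatic ring left in place, the change from 4-bromophenyl to 4-methoxyphenyl in this assay gives a 13-fold lower number from compound 3 to compound 4 (1.12 log units; beyond the scatter), so the group on this aromatic carbon, para to a large group, is shown for the first time to carry a large effect of its own. The ring itself therefore does not fix the number: carboxy(4-methoxyphenyl)methyl in place of 1-carboxy-1-methylethyl gives a 2.0-fold higher number from compound 2 to compound 4 (0.30 log units; within the scatter), while the exchange of the whole group on the nitrogen gives a 53-fold lower number from compound 1 to compound 4 (1.73 log units; beyond the scatter), a large step that still joins the change at this ring position with that from methoxycarbonyl to carboxy. Nothing measured here explains why methoxy and bromo differ so much.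

The compounds shown leave open whether hydroxy, amino or ethoxy on the same aromatic carbon would give a number close to that of the methoxy compound or to that of the bromo compound. They also leave open how much of the large step from the ester belongs to the carboxylic acid alone, which a methoxycarbonyl group on the 4-methoxyphenyl series would separate.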